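Moving the Thiophene Attachment Point in Compound 1

The source may hold more compounds than are shown below. What is called first, only, known or untested is meant among the compounds shown, and "the series" means these compounds.

Within the data shown here, compound 1 `Clc1ccc(-c2cc(-c3ccsc3)nc(-c3ccccc3Cl)c2)o1` is one of two compounds measured in a functional assay on HCT-15 cells (Homo sapiens) for cytotoxicity, in the presence of a further agent that is not named here (on this read-out higher numbers stand for weaker inhibition and lower numbers for stronger inhibition), where compound 1 gives 4570 nM. The other, compound 2 `Cc1cccc(-c2cc(-c3ccc(Cl)o3)cc(-c3ccsc3)n2)c1`, gives 21700 nM in this assay, so compound 1 has the lower of the two numbers. Among the measured compounds shown here, the single measured step, a 4.7-fold higher number from compound 1 to compound 2 (0.68 log units; beyond the scatter), concerns the 2-chlorophenyl group and says nothing directly about the thiophene. Compound 3 `Clc1ccc(-c2cc(-c3cccs3)nc(-c3ccccc3Cl)c2)o1` differs from compound 1 only in how the thiophene is attached: thiophen-2-yl in place of thiophen-3-yl on an aromatic carbon. For the measured compounds named here, no measured pair shows a change of this kind, so the expectation for compound 3 rests on compound 1 alone, with the expectation that this change of attachment point produces no step beyond the scatter. The estimated step of a 1.1-fold higher number from compound 1 to compound 3 (0.04 log units; within the scatter) is therefore expected to be small, in either direction. Compound 3 is estimated at 5000 nM in this assay, within a range from 2000 nM to 13000 nM.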

Compound 3, half-maximal inhibitory concentration: 6190 nM
Estimate against measurement, compound 3: 1.2-fold (0.09 log units) below; the range from low to high includes it.
By their numbers in this assay, from the lowest: compounds 1 and 3 (each within the scatter of the next); then compound 2.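

Placing thiophen-2-yl in the site of thiophen-3-yl, next to the ring nitrogen, gives a 1.4-fold higher number from compound 1 to compound 3 (0.13 log units; within the scatter) in this assay, so this read-out does not separate the two attachment points. Among these compounds, this is the first measured change at this position, and it shows that the thiophene can be joined through either ring carbon without a step beyond the scatter, unlike the step at the other place, a 4.7-fold higher number from compound 1 to compound 2 (0.68 log units; beyond the scatter), which lies beyond it. The data offer no explanation for why the two attachment points read alike.

All the compounds shown carry a thiophene at this position, so it remains open whether a morpholine, a simple amine or a plain phenyl would be tolerated there. Going by these compounds, it is also open whether the attachment points would still read alike with 3-methylphenyl in place of 2-chlorophenyl.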